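A few compounds are considered here, and "the series" means these few. Any claim that something is new, unique, unknown or untested is made for them only; others in the source may bear on it.

Measured so far:
compound 1 `CN1CCC(OC(=O)c2ccc(C(C)(C)C)cc2)CC1` gives 1.13
compound 2 `CN1CCC(OC(=O)c2ccc([N+](=O)[O-])cc2)CC1` gives 1.14

Among the measured compounds shown here, in a functional assay on the whole organism with Mus musculus as the target (a lower number here means a less potent compound, a higher number a more potent compound, by a factor of ten per unit of this negative logarithm), compound 2 stands at the top of these two numbers, yet the only measured step, a number 0.01 log units higher from compound 1 to compound 2 (within the scatter), lies within the scatter. Compound 3 `CN1CCC(OC(=O)c2ccc(C#N)cc2)CC1` carries the change (cyano in place of nitro on an aromatic carbon). For the measured compounds named here, no measured step exchanges cyano for nitro; the single step available, a number 0.01 log units higher from compound 1 to compound 2 (within the scatter), shows that swapping one group on the aromatic carbon left the number essentially unchanged, so a step within the scatter is expected, about a number 0.04 log units lower from compound 2 to compound 3 (within the scatter). Compound 3 is therefore estimated at 1.1, with a range from 0.7 to 1.5.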

Compound 3, logarithm of the reciprocal of the active concentration, log(1/C): 1.65
Compound 3: the middle estimate sits 0.55 log units below what was measured; the whole stated range lies below it.
By their numbers in this assay, from the lowest: compounds 1 and 2 (each within the scatter of the next); then compound 3.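

In this assay the group on this aromatic carbon does make a difference: cyano in place of nitro gives a number 0.51 log units higher from compound 2 to compound 3 (beyond the scatter) and cyano in place of tert-butyl gives a number 0.52 log units higher from compound 1 to compound 3 (beyond the scatter) while the earlier swap of tert-butyl for nitro had shown no separation. So the position is not indifferent to what it carries, and cyano stands apart from both other groups. No measurement presented here explains this difference. The compounds shown leave open whether the higher number belongs to cyano alone or would also appear with chlorine, an amine or a carboxylic acid at this place.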